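A few compounds are considered here, and "the series" means these few. Any claim that something is new, unique, unknown or untested is made for them only; others in the source may bear on it.

Measured in a functional assay on DU-145 cells (Homo sapiens) for inhibition, read by trypan blue exclusion, with a stated time of 96 h; a higher number here means a weaker inhibitor of growth, a lower number a stronger inhibitor of growth:
- Compound 1 `O=C(/C(=C\c1ccc(O)c([N+](=O)[O-])c1)SCc1ccc(Br)cc1)c1ccc(Br)cc1`: 10000 nM
- Compound 2 `O=C(/C(=C\c1ccc(O)c([N+](=O)[O-])c1)S(=O)(=O)c1ccc(I)cc1)c1ccc(I)cc1`: 25000 nM
- Compound 3 `O=C(/C(=C\c1ccc(O)c([N+](=O)[O-])c1)Sc1ccccc1Br)c1ccc(Br)cc1`: 10000 nM

Compound 3 stands level with compound 1, and together they hold the lowest number of the three. In this assay, a lower number means stronger inhibition of growth, so both sit ahead of compound 2, whose gap from them lies beyond the scatter.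

The next compound is compound 4 `O=C(/C(=C\c1ccc(O)c([N+](=O)[O-])c1)S(=O)(=O)c1ccc(I)cc1)c1ccc(Br)cc1`. Relative to compound 3, the change is (4-iodophenyl)sulfonyl in place of (2-bromophenyl)sulfanyl on a double-bonded chain carbon bound to a carbonyl carbon and a double-bonded chain carbon.

Going by the values given here, one measured step bears on this indirectly: no change at the digits printed from compound 1 to compound 3 (within the scatter). It exchanges one group on a sulfur for another, yet neither compound carries a sulfonyl group, so it cannot show what a sulfonyl group does here. The better guide is compound 2, which carries the same (4-iodophenyl)sulfonyl group and gives 25000 nM. A move towards that number therefore seems likely.

The expected change is a 2.0-fold higher number from compound 3 to compound 4 (0.30 log units; within the scatter), towards weaker inhibition. For compound 4 the estimated value is 20000 nM, with an expected range of 10000 nM to 40000 nM.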

Compound 4, concentration for 50% growth inhibition: 25000 nM
Compound 4: middle estimate off by 1.3-fold (0.10 log units), on the low side, within the range that was stated.
By their numbers in this assay, from the lowest: compounds 1 and 3 (each within the scatter of the next); then compounds 2 and 4 (each within the scatter of the next).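

In this assay, going by these compounds alone, the first compound here with a sulfonyl group on the chain carbon and a bromo-bearing aryl ketone shows what the swap of a sulfanyl group for (4-iodophenyl)sulfonyl does: it gives a 2.5-fold higher number from compound 3 to compound 4 (0.40 log units; beyond the scatter) and a 2.5-fold higher number from compound 1 to compound 4 (0.40 log units; beyond the scatter), so two different sulfanyl groups both lead to the same weaker result. Bromo in place of iodo on an aromatic carbon gives no change at the digits printed from compound 2 to compound 4 (within the scatter), so compound 2 and compound 4 cannot be told apart, and this halogen swap has no visible effect in this pair. Nothing measured here explains these differences.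

As far as these compounds go, each step from a sulfanyl compound alters the sulfur's oxygens and its aryl group at once, so the share of each stays open. From the compounds shown here alone, how an amine, a carboxylic acid or a longer chain would behave in place of (4-iodophenyl)sulfonyl on this carbon also remains unknown.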